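The compounds below may be only part of what the source reports. "The series", "measured", "known", "first", "only" and "open" are said of these compounds alone.

Going by the values given here, compound 1 `NC(=O)CCCCc1c[nH]c2ccc(F)cc12` is the only compound here with a definite number: in an assay on isolated protein (urine) for inhibition of Myeloperoxidase (Homo sapiens), with a stated time of 5 min (a higher number here means a weaker inhibitor, a lower number a stronger inhibitor), compound 1 gives 39 nM. Compound 2 `NCCCc1c[nH]c2ccc(C(=O)O)cc12` carries a carboxylic acid on the shared core in place of the fluorine and a shorter chain ending in an amine; in this assay compound 2 is reported as "not active" (no number reported). Compound 3 `CCSCCc1c[nH]c2ccc(F)cc12` is reported only as a limit of this assay, namely > 100 nM. Among the compounds with values here, the one computed step, an at least 2.5-fold higher number from compound 1 to compound 3 (0.40 log units; beyond the scatter), rests on that limit (the limit of > 100 nM in this assay, at which 1 of the 3 values shown sits), so the true size of the loss from compound 1 to compound 3 is not known.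

Compound 4 `CCNC(=O)CCCc1c[nH]c2ccc(F)cc12` has not yet been measured. Its difference from compound 1 is ethylcarbamoyl in place of carbamoylmethyl on a saturated chain carbon, three bonds along the chain from an aromatic carbon. The amide is kept but moved one chain carbon closer to the core, and an ethyl now sits on the amide nitrogen. Within the data shown here, no measured step touches this kind of change; the step to compound 3 removed the amide altogether, which is not the case here. The expectation is therefore a step of a 1.5-fold higher number from compound 1 to compound 4 (0.19 log units; within the scatter), within or just beyond the scatter. Compound 4 is estimated at 60 nM, with a range from 20 nM to 200 nM.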

Compound 4, half-maximal inhibitory concentration: 182 nM
Beside the measured number, compound 4's estimate is 3.0-fold (0.48 log units) below it; the range from low to high includes it.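

In this assay, keeping an amide on the chain is not enough to hold the activity of compound 1: ethylcarbamoyl in place of carbamoylmethyl gives a 4.7-fold higher number from compound 1 to compound 4 (0.67 log units; beyond the scatter). The earlier step replaced the amide altogether, whereas this one shows that the number at this chain position also responds when an amide remains. The step between compound 3 and compound 4 cannot be read because it rests on a limit: the limit of > 100 nM in this assay, at which 1 of the 4 values shown sits.

This change both moves the amide one chain carbon closer to the core and adds an ethyl on its nitrogen. Going by these compounds, the data do not separate these two changes, and how much of the loss belongs to each remains open. Also open, on these data alone, is how a methyl on the amide nitrogen, or a carboxylic acid in place of the amide, would fare on the fluorine-bearing core.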